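The compounds below may be only part of what the source reports. "The series", "measured", "known", "first", "only" and "open" are said of these compounds alone.

Among the compounds with values here, compound 2, `N/C(=N\NC(=S)N1CCCCC1)c1ccccn1`, gives 27% in a functional assay on A-431 cells (Homo sapiens) for cytotoxicity, read by MTT assay, with a stated time of 72 h, tested at 3 uM (on this read-out lower numbers stand for less inhibition of growth and higher numbers for more inhibition of growth at the one concentration tested), the lower of the two numbers measured so far. The nearest is compound 1, `Cc1ccnc(/C(N)=N/NC(=S)N2CCOCC2)c1`, which in this assay gives 35.5%; the gap between them lies within the usual scatter, so no order can be claimed. Compound 3, `Cc1ccnc(/C(N)=N/NC(=S)N2CCCCC2)c1`, differs from compound 2 by methyl in place of hydrogen on an aromatic carbon. Within the data shown here, no two measured compounds differ in a single place, so nothing shows what this change alone does. The step expected for it, a number 5 percentage points higher from compound 2 to compound 3 (within the scatter), stays within the scatter. Compound 3 is therefore estimated at 32%, ranging from 15% to 50%.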

Compound 3, percent growth inhibition at one concentration: 36.5%
Compound 3: middle estimate off by 4.5 percentage points, on the low side; measured number inside the range.
By their numbers in this assay, from the lowest: compounds 2, 1 and 3 (each within the scatter of the next).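

In this assay, methyl in place of hydrogen on the aromatic carbon opposite the ring nitrogen gives a number 9.5 percentage points higher from compound 2 to compound 3 (within the scatter), so at this position the two groups cannot be told apart. Piperidin-1-yl in place of morpholin-4-yl on the thiocarbonyl carbon gives a number 1 percentage points higher from compound 1 to compound 3 (within the scatter), and these two groups cannot be told apart either. No measured evidence bears on either step. Going by these compounds, it remains open whether an amine, a carboxylic acid or a longer chain at the aromatic position would shift the number beyond the scatter.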